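Five- versus six-membered amine ring at the thiocarbonyl carbon

The compounds below may be only part of what the source reports. "The series", "measured", "known", "first", "only" and "open" are said of these compounds alone.

compound 1 `Cc1ccc2c(=O)c(CSC(=S)N3CCCCC3)coc2c1`: 800 nM
compound 2 `COc1ccc2occ(CSC(=S)N(C(C)C)C(C)C)c(=O)c2c1`: > 40000 nM (a limit)
compound 3 `O=c1cc(CSC(=S)N2CCCCC2)oc2cc(Cl)ccc12`: > 25000 nM (a limit)

In a functional assay on MCF7 cells (Homo sapiens) for antiproliferative activity, read by MTT assay, with a stated time of 72 h (on this read-out higher numbers stand for weaker inhibition and lower numbers for stronger inhibition), compound 1 gives 800 nM. For compound 2 this assay reports only a limit, > 40000 nM. For compound 3 it likewise reports only a limit, > 25000 nM. For the measured compounds named here, compound 1 therefore holds the only measured number in the set, the two other entries standing at limits (the limit of > 25000 nM in this assay, at which 1 of the 3 values shown sits, and (the limit of > 40000 nM in this assay, at which 1 of the 3 values shown sits)). Compound 4 `Cc1ccc2c(=O)c(CSC(=S)N3CCCC3)coc2c1` has not yet been measured in this assay. It differs from compound 1 by pyrrolidin-1-yl in place of piperidin-1-yl on a thiocarbonyl carbon. Going by the values given here, no step between measured compounds exists that would gauge this change. The expected step from compound 1 to compound 4 is a 1.5-fold higher number from compound 1 to compound 4 (0.18 log units; within the scatter), nothing beyond the usual scatter. Compound 4 is accordingly estimated at 1200 nM, in a range of 400 nM to 4000 nM.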

Compound 4, half-maximal inhibitory concentration: 41400 nM
The estimate for compound 4 lay 35-fold (1.54 log units) below the measured number, and the stated range ends below it.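

In this assay, the amine ring on the thiocarbonyl carbon turns out to be a sensitive position: pyrrolidin-1-yl in place of piperidin-1-yl gives a 52-fold higher number from compound 1 to compound 4 (1.71 log units; beyond the scatter). For the compounds shown here, this is the first step that gauges this position on an unchanged core, and the change is far from neutral. Nothing measured here accounts for the size of the step.

As far as these compounds go, whether the step follows ring size alone remains open. An azepan-1-yl or morpholin-4-yl ring on the core of compound 1 would test this, and whether the step carries over to other cores is also unresolved.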